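Swapping the Chain Hydroxyl for an Acetamide

A few compounds are considered here, and "the series" means these few. Any claim that something is new, unique, unknown or untested is made for them only; others in the source may bear on it.

Measured so far in a functional assay on HT cells (Homo sapiens) for antiproliferative activity, read by fluorescence, with a stated time of 72 h; on this read-out higher numbers stand for weaker inhibition of growth and lower numbers for stronger inhibition of growth:
Compound 1, `CC(C)c1n[nH]c2c(NCc3ccc(-c4ccccn4)cc3)nc(SCC(N)CN)nc12`, gives 480 nM.
Compound 2, `CC(C)c1n[nH]c2c(NCc3ccc(-c4ccccn4)cc3)nc(SCC(C)(C)O)nc12`, gives 507 nM.
Compound 3, `CC(C)c1n[nH]c2c(NCc3ccc(-c4ccccn4)cc3)nc(SCCCO)nc12`, gives 109 nM.

All three share one core and differ only in the chain on the sulfur. Compound 3 stands lowest of the three numbers in this assay: the steps of a 4.4-fold lower number from compound 1 to compound 3 (0.64 log units; beyond the scatter) and a 4.7-fold lower number from compound 2 to compound 3 (0.67 log units; beyond the scatter) both lie beyond the scatter, whereas a 1.1-fold higher number from compound 1 to compound 2 (0.02 log units; within the scatter) does not, so compound 1 and compound 2 cannot be ordered against each other.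

Compound 4, `CC(=O)NCCSc1nc(NCc2ccc(-c3ccccn3)cc2)c2[nH]nc(C(C)C)c2n1`, is not yet measured. It differs from compound 3 in one place: acetamido in place of hydroxymethyl on a saturated chain carbon, two bonds along the chain from a sulfur. Among the measured compounds shown here, no measured pair makes this exact change, so the guidance is indirect. Both other variations of the chain end, read from compound 3, raised the number by a modest amount, as a 4.4-fold lower number from compound 1 to compound 3 (0.64 log units; beyond the scatter) and a 4.7-fold lower number from compound 2 to compound 3 (0.67 log units; beyond the scatter) show in reverse. Since the entering group carries more heavy atoms than the hydroxymethyl it replaces, a modest rise is expected for compound 4, about a 2.3-fold higher number from compound 3 to compound 4 (0.36 log units; beyond the scatter), though the lack of a direct precedent leaves the range wide. Compound 4 is therefore estimated at 250 nM, between 100 nM and 700 nM.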

Compound 4, concentration for 50% growth inhibition: 71 nM
The estimate for compound 4 lay 3.5-fold (0.55 log units) above the measured number; the measured number lies below the stated range.
By their numbers in this assay, from the lowest: compounds 4 and 3 (each within the scatter of the next); then compounds 1 and 2 (each within the scatter of the next).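

A step of a 1.5-fold lower number from compound 3 to compound 4 (0.19 log units; within the scatter) in this assay shows that, two bonds along the chain from a sulfur, acetamido can replace hydroxymethyl with no readable change, even though it carries more heavy atoms. The low number at this position is therefore not unique to the hydroxyl end of compound 3, and steps of a 7.1-fold lower number from compound 2 to compound 4 (0.85 log units; beyond the scatter) and a 6.8-fold lower number from compound 1 to compound 4 (0.83 log units; beyond the scatter) set compound 4 clearly apart from both of the weaker chains, as compound 3 is. Nothing measured here explains why these two chain ends behave alike.

The compounds shown leave open whether a single amine or a carboxylic acid at the chain end would keep the number this low. They also leave open whether a longer chain carrying the same acetamido would do so.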